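The source may hold more compounds than are shown below. What is called first, only, known or untested is meant among the compounds shown, and "the series" means these compounds.

Compound 1 `Cc1nc(C)n2c(S)nncc12` — in a functional assay for inhibition, with Homo sapiens as the target (a higher number here means a weaker inhibitor, a lower number a stronger inhibitor), compound 1 gives > 48000 nM, which is a limit of the assay.
Compound 2 `Cc1ncn2c(S)nncc12` — in this assay compound 2 gives > 48000 nM, also a limit.

Compound 2 thus stands only at a limit in this assay, not at a number. Among the measured compounds shown here, the step from compound 1 to compound 2 is a step that the two limits leave unreadable from compound 1 to compound 2, so it shows nothing about hydrogen in place of methyl on an aromatic carbon; the only evidence is the limit of > 48000 nM in this assay, at which 2 of the 2 values shown sit. Compound 3 `Cc1ncn2c(NN)nncc12` differs from compound 2 by aminoamino in place of sulfanyl on an aromatic carbon. For the measured compounds named here, no measured step bears on this change. The step is expected to be a step that the limit leaves unreadable from compound 2 to compound 3, with no direction foreseeable. Compound 3 is estimated at 60000 nM, within 15000 nM to 300000 nM.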

Compound 3, half-maximal inhibitory concentration: > 48000 nM
Compound 3 gave a limit, no number; the forecaster's own chance of this, stated with the estimate: 80%; the middle value is on the limit's open side.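

Among the compounds shown here, compound 3 also gives only a limit, > 48000 nM, so no step from compound 2 to compound 3 can be read. The compounds shown leave open how strongly any of them inhibits, as all rest at one limit: the limit of > 48000 nM in this assay, at which 3 of the 3 values shown sit.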